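The source may report more compounds than this note shows. Statements on the series, on what has been measured and on what is new or still open speak of the compounds shown alone.

Series notes. In a functional assay on MKN-45 cells (Homo sapiens) for cytotoxicity, read by MTT assay, with a stated time of 72 h (a lower number here means a stronger inhibitor, a higher number a weaker inhibitor), compound 1 `COc1cc2c(Oc3ccc(NC(=O)c4nn(-c5ccc([N+](=O)[O-])cc5)c(=O)c5ccccc45)cc3F)ccnc2cc1OCCCN1CCCC1` gives 1620 nM. Compound 2 `COc1cc2c(Oc3ccc(NC(=O)c4nn(-c5ccc(Br)cc5)c(=O)c5ccccc45)cc3F)ccnc2cc1OCCCN1CCCCC1` differs from compound 1 at two places at once, the group on the pendant aromatic ring and the size of the saturated amine ring on the side chain, and in this assay compound 2 gives 500 nM. Among the measured compounds shown here, compound 2 therefore holds the lowest of the two numbers measured so far, with compound 1 higher and beyond the scatter. The two measured compounds do not separate which of the two changes carries that gap.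

Compound 3 `COc1cc2c(Oc3ccc(NC(=O)c4nn(-c5ccc([N+](=O)[O-])cc5)c(=O)c5ccccc45)cc3F)ccnc2cc1OCCCN1CCCCC1` is the next step from compound 2: nitro in place of bromo on an aromatic carbon. Compound 3 keeps the amine ring of compound 2 but takes the aromatic substituent of compound 1. With no single-change comparison available, a modest rise in the number is expected, around the edge of the scatter, so that a 2.0-fold higher number from compound 2 to compound 3 (0.30 log units; within the scatter) is the expected step. For compound 3 the expected value is 1000 nM, between 400 nM and 2500 nM.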

Compound 3, half-maximal inhibitory concentration: 1140 nM
For compound 3 the middle estimate is 1.1-fold (0.06 log units) below the measured one, within the range that was stated.
By their numbers in this assay, from the lowest: compound 2; then compounds 3 and 1 (each within the scatter of the next).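

In this assay, among the compounds shown here, with the piperidin-1-yl side chain held, 4-nitrophenyl in place of 4-bromophenyl gives a 2.3-fold higher number from compound 2 to compound 3 (0.36 log units; beyond the scatter) and is the one step here beyond the scatter. With the 4-nitrophenyl group held, piperidin-1-yl in place of pyrrolidin-1-yl gives a 1.4-fold lower number from compound 1 to compound 3 (0.15 log units; within the scatter), so of the two changes that were tangled in the first pair, only the substituent on the pendant aromatic ring shows a readable effect. No measurement shown here bears on why the substituent matters in this way.

On these data alone, whether bromo keeps its lower number on the pyrrolidin-1-yl side chain remains open, as each change is read on one background only. As far as these compounds go, how a methoxy or an amino group at this place, or a morpholin-4-yl ring on the side chain, would compare also remains open.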